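The source may report more compounds than this note shows. Statements on the series, on what has been measured and on what is new or still open speak of the compounds shown alone.

Measured so far in an assay on cells for inhibition of protein deacetylase HDAC6 (Homo sapiens), with a stated time of 3 h; a higher number here means a weaker inhibitor, a lower number a stronger inhibitor:
compound 1, `O=C(CCCCCCC(=O)Nc1ccc2ccnc(Nc3ccc(Br)cc3F)c2c1)NO` — 6.83 nM
compound 2, `Cc1ccc(Nc2nccc3ccc(NC(=O)CCCCCCC(=O)NO)cc23)c(Br)c1` — 6.26 nM
compound 3, `O=C(CCCCCCC(=O)Nc1ccc2ccnc(Nc3ccccc3F)c2c1)NO` — 11 nM

All three share one core and differ only in the aryl group on the nitrogen on an aromatic ring. In this assay compound 3 gives the highest of the three numbers, but the separation is small: a 1.6-fold higher number from compound 1 to compound 3 (0.21 log units; within the scatter) and a 1.8-fold higher number from compound 2 to compound 3 (0.24 log units; within the scatter). Compounds 1 and 2 are likewise close, a 1.1-fold lower number from compound 1 to compound 2 (0.04 log units; within the scatter). None of these steps goes beyond the scatter, so no order among the three can be stated.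

Compound 4, `COCCCNc1nccc2ccc(NC(=O)CCCCCCC(=O)NO)cc12`, has not yet been measured in this assay. Relative to compound 3 the change is 3-methoxypropyl in place of 2-fluorophenyl on a nitrogen on an aromatic ring. The three measured steps all exchange one substituted phenyl for another and bear on this change only loosely; none removes the aromatic ring from the nitrogen on an aromatic ring, and none moved the number beyond the scatter. For the measured compounds named here, the nearest precedent therefore points to little movement, but the present change is of a different kind from any measured step, so the range is set wider than those steps alone would justify. The expected step is a 1.4-fold higher number from compound 3 to compound 4 (0.13 log units; within the scatter). Compound 4 is estimated at 15 nM, with a range of 5 nM to 45 nM.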

Compound 4, half-maximal inhibitory concentration: 13.6 nM
Compound 4: the middle estimate sits 1.1-fold (0.04 log units) above what was measured; low and high end bracket the measured number.
By their numbers in this assay, from the lowest: compounds 2, 1, 3 and 4 (each within the scatter of the next, the first and the last beyond it).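

In this assay, 3-methoxypropyl in place of 2-fluorophenyl on the nitrogen on an aromatic ring gives (a 1.2-fold higher number from compound 3 to compound 4 (0.09 log units; within the scatter)), so at this position a chain with no ring stays within the scatter of compound 3, and an aryl group is not required for a number of this size. For the compounds shown here, the comparison with the other two aryl groups is less even: the change from 4-bromo-2-fluorophenyl gives (a 2.0-fold higher number from compound 1 to compound 4 (0.30 log units; within the scatter)), while the change from 2-bromo-4-methylphenyl gives (a 2.2-fold higher number from compound 2 to compound 4 (0.34 log units; beyond the scatter)), the only modest step beyond the scatter in the set, with compound 1 and compound 3 going against any general separation of aryl from chain. No measurement among the compounds shown accounts for these steps.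

From the compounds shown here alone, whether the oxygen of the 3-methoxypropyl group matters stays open, as a plain propyl or butyl chain would be needed to read it on its own. Also open, going by these compounds, is how an amine or a carboxylic acid at the end of the chain, or a longer chain, would behave on this nitrogen in this assay.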